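One Methoxy Group Removed, Cell Toxicity Compared

This account rests on a few compounds, and the source may have more. Where it says the series, first, only, none or still open, it means among the compounds named here.

Three compounds sharing a core were measured: compound 1 `COc1ccc(-c2cc(/C=C/C(=O)c3ccc(N)cc3)[nH]n2)cc1`, compound 2 `COc1ccc(-c2cc(/C=C/C(=O)c3ccc(N)cc3)[nH]n2)cc1OC` and compound 3 `COc1cc(C(=O)/C=C/c2cc(-c3cc(OC)c(OC)c(OC)c3)n[nH]2)cc(OC)c1OC`. In a functional assay on SF-539 cells (Homo sapiens) for inhibition, read by sulforhodamine B assay, with a stated time of 48 h (on this read-out lower numbers stand for higher toxicity in this test and higher numbers for lower toxicity in this test), compound 1 gives 8250 nM, compound 2 gives 7190 nM, and compound 3 gives 6230 nM. The change from compound 2 to compound 1 is hydrogen in place of methoxy on an aromatic carbon; it made a 1.1-fold higher number from compound 2 to compound 1 (0.06 log units; within the scatter). How the cores of compound 2 and compound 3 differ is not broken down here.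

Compound 4 `COc1ccc(-c2cc(/C=C/C(=O)c3cc(OC)c(OC)c(OC)c3)[nH]n2)cc1OC` has not yet been measured in this assay. It arises from compound 3 by hydrogen in place of methoxy on an aromatic carbon, the same kind of change as from compound 2 to compound 1, though here the place is also meta to a methoxy group. Because the earlier step was a 1.1-fold higher number from compound 2 to compound 1 (0.06 log units; within the scatter), compound 4 is expected to show a 1.1-fold higher number from compound 3 to compound 4 (0.05 log units; within the scatter), landing near an estimated 7000 nM, with a likely range from 3500 nM to 14000 nM.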

Compound 4, concentration lethal to 50% of the cells: 4570 nM
For compound 4 the middle estimate is 1.5-fold (0.19 log units) above the measured one; the range from low to high includes it.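

In this assay, hydrogen in place of methoxy on an aromatic carbon gave a 1.4-fold lower number from compound 3 to compound 4 (0.13 log units; within the scatter). Set beside the earlier step, the new one does not separate from it: the same change on two cores in this assay, a 1.1-fold higher number (0.06 log units; within the scatter) from compound 2 to compound 1 and a 1.4-fold lower number (0.13 log units; within the scatter) from compound 3 to compound 4, 1.6-fold (0.19 log units) apart, within the scatter of two such steps. On these two cores, then, the change left the number within the scatter both times and gave no sign that the core matters, but two pairs cannot show that the same would hold on any other core or in any other test.

The compounds shown leave open what a group other than hydrogen would do in this place. A hydroxy group, a fluorine or a longer chain such as ethoxy might yet give a step beyond the scatter.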